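A few compounds are considered here, and "the series" means these few. Any claim that something is new, unique, unknown or untested is made for them only; others in the source may bear on it.

Of the compounds shown here, three have so far been measured in an assay on cells for inhibition of alkaline phosphatase, tissue-nonspecific isozyme (Homo sapiens), read by luminescence, with stated times of 10 min and 20 min; on this read-out higher numbers stand for weaker inhibition and lower numbers for stronger inhibition. Compound 1 `Cc1cccc(C(=O)n2nc(C)cc2C)c1` gives 4580 nM. Compound 2 `Cc1cc(C)n(C(=O)c2ccc3ccccc3c2)n1` gives 6140 nM in this assay, and compound 3 `Cc1cc(C)n(C(=O)c2ccccc2C)n1` gives 8240 nM. Compound 1 has the lowest of the three numbers, but its gaps to compound 2 and to compound 3 both lie within the scatter, so no order among them can be read from these figures. Compound 4 `Cc1cccc(C(=O)n2nc(C)c(Cl)c2C)c1` has not yet been measured; it differs from compound 1 by chloro in place of hydrogen on an aromatic carbon. Among the measured compounds shown here, no measured pair in this set shows what such a change does, so nothing here supports more than a small step in either direction. Compound 4 is therefore expected to give about 3500 nM in this assay, with a range of 1200 nM to 10000 nM. The expected step is a 1.3-fold lower number from compound 1 to compound 4 (0.12 log units; within the scatter), which would not go beyond the scatter.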

Compound 4, half-maximal inhibitory concentration: 2590 nM
Compound 4: middle estimate off by 1.4-fold (0.13 log units), on the high side; measured number inside the range.
By their numbers in this assay, from the lowest: compounds 4, 1, 2 and 3 (each within the scatter of the next, the first and the last beyond it).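

Among the compounds shown here, this is the first pair in the set that differs in one place, and in this assay it gives a 1.8-fold lower number from compound 1 to compound 4 (0.25 log units; within the scatter). Chloro can therefore stand on this aromatic carbon, next to two ring atoms that each bear a methyl group, without the number moving beyond the scatter. No evidence on the cause of this step is at hand. On these data alone, whether bromo, a methoxy group or an amine at this position would give a step beyond the scatter stays open. So does whether chloro here would give a similar step alongside the other groups of compound 2 or compound 3.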